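The source may report more compounds than this note shows. Statements on the series, on what has been measured and on what is new or still open speak of the compounds shown alone.

In a functional assay on NALM-6 cells (Homo sapiens) for cytotoxicity, with a stated time of 72 h (a lower number here means that less compound is needed, a higher number that more compound is needed for the effect), compound 1 `CC(C)=CCC[C@@](C)(/C=C/c1ccc(C)cc1)/C=C/c1ccc(O)cc1` gives > 43400 nM, a limit of the assay and not a number. Compound 2 `CC(C)=CCC[C@](C)(/C=C/c1ccc(O)cc1)/C=C/c1ccc(C#N)cc1` gives > 43400 nM, also a limit. Compound 3 `CC(C)=CCC[C@](C)(/C=C/c1ccc(O)cc1)/C=C/c1cccc(F)c1` gives > 43400 nM, again a limit, so it has no number of its own. The three compounds stand together at the limit of > 43400 nM in this assay, at which 3 of the 3 values shown sit. Compound 4 `CC(C)=CCC[C@](C)(/C=C/c1ccc(O)cc1)/C=C/c1cccc(Cl)c1` carries chloro in place of fluoro on an aromatic carbon of compound 3: chloro in place of fluoro on an aromatic carbon. For the measured compounds named here, three measured steps bear on this change: a step that the two limits leave unreadable from compound 1 to compound 3, a step that the two limits leave unreadable from compound 2 to compound 3 and a step that the two limits leave unreadable from compound 1 to compound 2. None of them has a readable size, so they offer no direction, although changes to this aromatic ring have so far left every reading at the limit. In this assay, no change beyond the scatter is expected, and the estimated step is an at least 1.0-fold lower number from compound 3 to compound 4 (0.03 log units; that floor lies within the scatter). Compound 4 is expected at about 40000 nM, with an estimated range from 15000 nM to 60000 nM.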

Compound 4, half-maximal effective concentration: > 43400 nM
Compound 4 was reported as a limit; the forecaster's own chance of this, stated with the estimate: 75%; middle value at least 1.0-fold (0.03 log units) away from the limit.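

In this assay compound 4 gives > 43400 nM, which is a limit of the assay. For the compounds shown here, no step among compound 1, compound 2, compound 3 and compound 4 can therefore be read. The compounds shown leave open what number each would give and whether any change to this aromatic ring alters it.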